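The compounds below may be only part of what the source reports. "The series", "measured", "known", "first", "only" and "open" are said of these compounds alone.

Measured compounds in a functional assay on CCRF-CEM cells for antagonist activity at C-X-C chemokine receptor type 4 (Homo sapiens), read by calcium flux, with stated times of 25 min and 90 s; on this read-out higher numbers stand for weaker inhibition and lower numbers for stronger inhibition:
compound 1, `c1cnc2c(c1)CCC[C@@H]2N(CC1CCCCC1)C[C@H]1Cc2c(cccc2N2CCNCC2)CN1`, 715 nM;
compound 2, `CN(C[C@H]1Cc2c(cccc2N2CCN(c3cccc(C(F)(F)F)c3)CC2)CN1)[C@H]1CCCc2cccnc21`, reported only as a limit, > 16700 nM.

Going by the values given here, compound 1 carries the only numerical value shown in this assay. For compound 2 the read-out gives no number, only (the limit of > 16700 nM in this assay, at which 1 of the 2 values shown sits). Compound 2 also differs from compound 1 in more than one place, so its result tells nothing about any single change.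

The step followed here leads from compound 1 to compound 3, `CC(C)N(C[C@H]1Cc2c(cccc2N2CCNCC2)CN1)[C@H]1CCCc2cccnc21`. The change is isopropyl in place of cyclohexylmethyl on an amine nitrogen. Among the compounds with values here, no measured pair shows this change in isolation, so the size of the step has to be judged without a direct precedent. He would expect the replacement of the larger cyclohexylmethyl by the smaller isopropyl to cost potency, with a loss beyond the usual scatter, though not to the point of losing all activity, which is the step of a 4.2-fold higher number from compound 1 to compound 3 (0.62 log units; beyond the scatter) he estimates. For compound 3 in this assay the value is accordingly expected at about 3000 nM, with a likely range from 800 nM to 12000 nM.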

Compound 3, half-maximal inhibitory concentration: 364 nM
The estimate for compound 3 lay 8.2-fold (0.92 log units) above the measured number; the measured number lies below the stated range.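

On this amine nitrogen, in this assay, exchanging cyclohexylmethyl for isopropyl gives a 2.0-fold lower number from compound 1 to compound 3 (0.29 log units; within the scatter), so the two compounds cannot be told apart on this read-out. The substituent here can thus go from 7 heavy atoms to 3 and lose its six-membered ring of carbon without any difference beyond the scatter, which means that this ring is not required for the activity level seen in compound 1. Nothing measured on these compounds explains why the two groups give matching results, and no available evidence bears on this step.

On these data alone, only these two groups can be compared directly at this nitrogen, so it remains open whether a longer chain, a benzyl group or a chain ending in an amine or a carboxylic acid would give a similar value. As far as these compounds go, it is also open whether the same freedom at this nitrogen would hold if the rest of the molecule differed from the shared core of compound 1 and compound 3.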